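The compounds below may be only part of what the source reports. "The series", "measured", "known", "first", "only" and "open" are said of these compounds alone.

Compound 1, whose structure is `N#CC1=C(N)Oc2c(c3nc4ccccc4nc3c3ccccc23)C12C(=O)N(Cc1cnnn1-c1ccc(F)cc1)c1ccccc12`, is the starting point of three related compounds examined in an ADME assay on HUVEC cells (Homo sapiens) for antiproliferative activity, read by MTT assay, with a stated time of 48 h; a higher number here means a weaker inhibitor, a lower number a stronger inhibitor. In that test compound 1 gives > 50000 nM, which is a limit of the assay rather than a number. The same edge is reached elsewhere: the limit of > 50000 nM in this assay, at which 2 of the 3 values shown sit. Compound 2, `N#CC1=C(N)Oc2c(c3nc4ccccc4nc3c3ccccc23)C12C(=O)N(Cc1cnnn1-c1cccc(S(N)(=O)=O)c1)c1ccccc12`, carries a 3-sulfamoylphenyl in place of the 4-fluorophenyl on an aromatic nitrogen, and in this assay compound 2 gives 38600 nM. That change produced an at least 1.2-fold lower number from compound 1 to compound 2 (0.11 log units; that floor lies within the scatter). Compound 3, `Cc1ccc(C)c(-n2nncc2CN2C(=O)C3(C(C#N)=C(N)Oc4c3c3nc5ccccc5nc3c3ccccc43)c3ccccc32)c1`, has a 2,5-dimethylphenyl at the same position. In this assay compound 3 gives > 50000 nM, again a limit. The two limits give a step that the two limits leave unreadable from compound 1 to compound 3, while between the measured number and the limit there is an at least 1.2-fold higher number from compound 2 to compound 3 (0.11 log units; that floor lies within the scatter).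

The compound not yet measured is compound 4, `Cc1cc(C)cc(-n2nncc2CN2C(=O)C3(C(C#N)=C(N)Oc4c3c3nc5ccccc5nc3c3ccccc43)c3ccccc32)c1`. It differs from compound 1 thus: 3,5-dimethylphenyl in place of 4-fluorophenyl on an aromatic nitrogen. The step that bears most on it is that from compound 1 to compound 3, where a dimethylphenyl also replaced the 4-fluorophenyl and nothing moved off the limit. For compound 4 the expected result in this assay is 60000 nM, with a range from 30000 nM to 150000 nM, most likely reported only as a limit. That estimate means an expected step that the limit leaves unreadable from compound 1 to compound 4, nothing beyond the scatter.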

Compound 4, half-maximal inhibitory concentration: > 50000 nM
Compound 4: no number, only a limit; the forecaster's own chance of this, stated with the estimate: 75%; the middle value is on the limit's open side.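

On the aromatic nitrogen of the five-membered ring, the 3,5-dimethylphenyl of compound 4 ends at the same edge as the 2,5-dimethylphenyl of compound 3 and the 4-fluorophenyl of compound 1, so a second arrangement of the two methyl groups on this phenyl ring also yields no number, only a limit: the limit of > 50000 nM in this assay, at which 3 of the 4 values shown sit.

The steps among compound 1, compound 3 and compound 4 each join one limit to another, and none of them can be read. The one step that can be read is an at least 1.2-fold higher number from compound 2 to compound 4 (0.11 log units; that floor lies within the scatter), so the 3-sulfamoylphenyl of compound 2 remains the only group here that gives a number, and it is not shown to differ from the 3,5-dimethylphenyl.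

As far as these compounds go, how far compound 1, compound 3 and compound 4 lie beyond the limit stays open, and so does whether they differ from one another at all. Also open, from the compounds shown here alone, is what a phenyl ring carrying an amine or a carboxylic acid would give at this place, and whether any such group would bring the number clearly below that of compound 2.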